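Ring substituent swaps on a shared core, cytotoxicity series

The compounds below may be only part of what the source reports. "The series", "measured", "known", "first", "only" and "open" are said of these compounds alone.

Measured so far in a functional assay on SW-620 cells (Homo sapiens) for cytotoxicity, read by sulforhodamine B assay, with a stated time of 48 h; on this read-out lower numbers stand for stronger inhibition and higher numbers for weaker inhibition:
compound 1 `C[C@H]1CC[C@@H]2[C@@H](OC(=O)[C@]23CC(c2ccccc2F)=NO3)[C@]2(C)C(=O)C=C[C@@]12O` gives 11000 nM
compound 2 `Cc1ccccc1C1=NO[C@]2(C1)C(=O)O[C@@H]1[C@H]2CC[C@H](C)[C@]2(O)C=CC(=O)[C@@]12C` gives 5000 nM
compound 3 `Cc1ccc(C2=NO[C@]3(C2)C(=O)O[C@@H]2[C@H]3CC[C@H](C)[C@]3(O)C=CC(=O)[C@@]23C)cc1` gives 2500 nM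

Compound 3 carries the lowest number of the three, but toward compound 2 the step of a 2.0-fold lower number from compound 2 to compound 3 (0.30 log units; within the scatter) lies within the scatter, so no order between these two is claimed. Against compound 1 the step of a 4.4-fold lower number from compound 1 to compound 3 (0.64 log units; beyond the scatter) is beyond the scatter. The change from compound 2 to compound 1 is fluoro in place of methyl on an aromatic carbon and produced a 2.2-fold higher number from compound 2 to compound 1 (0.34 log units; beyond the scatter).

Compound 4 `C[C@H]1CC[C@@H]2[C@@H](OC(=O)[C@]23CC(c2ccc(F)cc2)=NO3)[C@]2(C)C(=O)C=C[C@@]12O` is not yet measured. It differs from compound 3 by fluoro in place of methyl on an aromatic carbon. The two cores differ by 4-methylphenyl in place of 2-methylphenyl on a carbon with a double bond to nitrogen: in the earlier pair the changed aromatic carbon is ortho to a large group, in the new pair it is para to a large group, so this is the same kind of change, not the same one.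

Within the data shown here, for compound 4 the step of a 2.0-fold higher number from compound 3 to compound 4 (0.30 log units; within the scatter) is expected, of about the size of the earlier one, because a 2.2-fold higher number from compound 2 to compound 1 (0.34 log units; beyond the scatter) is the only guide available. Compound 4 is therefore estimated at 5000 nM, with an expected range from 2000 nM to 12000 nM.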

Compound 4, half-maximal inhibitory concentration: 3600 nM
Estimate against measurement, compound 4: 1.4-fold (0.14 log units) above; measured number inside the range.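

In this assay, the change of fluoro in place of methyl on an aromatic carbon, here para to a large group, gives a 1.4-fold higher number from compound 3 to compound 4 (0.16 log units; within the scatter) and so sets no order between that pair, and its size agrees with the step on the other core: the same change on two cores in this assay, a 2.2-fold higher number (0.34 log units; beyond the scatter) from compound 2 to compound 1 and a 1.4-fold higher number (0.16 log units; within the scatter) from compound 3 to compound 4, 1.5-fold (0.18 log units) apart, within the scatter of two such steps

Among these compounds, this agreement shows that the change can be carried between these two cores without a detectable difference in step size, but it does not show a reproducible effect of the change, since only one of the two steps lies beyond the scatter and only two pairs are available. Of the swaps of the whole aryl group, a 1.4-fold lower number from compound 2 to compound 4 (0.14 log units; within the scatter) sets no order, whereas a 3.1-fold lower number from compound 1 to compound 4 (0.49 log units; beyond the scatter) separates that pair, so 4-fluorophenyl and 2-fluorophenyl are distinguished on this read-out.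

The compounds shown leave open whether a chloro or methoxy group, an amine or a carboxylic acid in these ring positions would follow the same pattern. On these data alone, the meta position of the ring also remains open, as does any replacement of the aromatic ring itself.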